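Swapping the aryl group on compound 1

This account rests on a few compounds, and the source may have more. Where it says the series, first, only, none or still open, it means among the compounds named here.

Measured compounds:
compound 1 `CCNC(=O)c1cc(Oc2ccc(NC(=O)c3nn(-c4ccc(Br)cc4F)c(=O)cc3C)cc2)ccn1`: 34500 nM
compound 2 `CCCNC(=O)c1cc(Oc2ccc(NC(=O)c3nn(-c4ccc(C)cc4)c(=O)cc3C)cc2F)ccn1`: 18000 nM
compound 3 `CNC(=O)c1cc(Oc2ccc(NC(=O)c3nn(-c4ccccc4Cl)c(=O)cc3C)cc2F)ccn1`: 11800 nM

In a functional assay on A549 cells (Homo sapiens) for antiproliferative activity, read by MTT assay, with a stated time of 72 h (on this read-out lower numbers stand for stronger inhibition and higher numbers for weaker inhibition), compound 1 gives 34500 nM and lies within the scatter of compound 2, but stands beyond the scatter above compound 3. Compound 4 `CCNC(=O)c1cc(Oc2ccc(NC(=O)c3nn(-c4ccc(C)cc4)c(=O)cc3C)cc2)ccn1` carries 4-methylphenyl in place of 4-bromo-2-fluorophenyl on an aromatic nitrogen. Among the measured compounds shown here, compound 2 has the same 4-methylphenyl group and gives 18000 nM in this assay, but it also differs from compound 4 elsewhere, so no measured pair isolates this change. Only a small move toward lower numbers is expected, not one beyond the scatter. The expected change is a 1.6-fold lower number from compound 1 to compound 4 (0.22 log units; within the scatter) overall. For compound 4 the estimated value is 21000 nM, with an expected range from 9000 nM to 50000 nM.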

Compound 4, half-maximal inhibitory concentration: 11600 nM
Beside the measured number, compound 4's estimate is 1.8-fold (0.26 log units) above it; low and high end bracket the measured number.
By their numbers in this assay, from the lowest: compounds 4, 3, 2 and 1 (each within the scatter of the next, the first and the last beyond it).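

In this assay, putting 4-methylphenyl in place of 4-bromo-2-fluorophenyl on the aromatic nitrogen gives a 3.0-fold lower number from compound 1 to compound 4 (0.47 log units; beyond the scatter) with nothing else in the structure altered. This is the only single-place comparison among these compounds, and it shows that this aryl group alone can move the number beyond the scatter. Nothing available here explains the step.

The compounds shown do not separate the loss of bromine, the loss of fluorine and the gain of methyl. On these data alone, how a plain phenyl or a 4-methoxyphenyl group would behave on this nitrogen also stays open.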